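A few compounds are considered here, and "the series" means these few. Any claim that something is new, unique, unknown or untested is made for them only; others in the source may bear on it.

Of the compounds shown here, three sharing one core have been measured in an ADME assay on NHDF cells (Homo sapiens) for cytotoxicity, read by MTT assay, with a stated time of 72 h; on this read-out higher numbers stand for weaker inhibition and lower numbers for stronger inhibition. Compound 1 (`COc1cccc(/C=C2\CCC/C(=C\c3ccc(Br)cc3)C2=O)c1OC`) gives 21400 nM, compound 2 (`COc1ccc(/C=C2\CCC/C(=C\c3cccc(OC)c3OC)C2=O)cc1`) gives 43500 nM, and compound 3 (`COc1ccccc1/C=C1\CCC/C(=C\c2ccc(OC)c(OC)c2)C1=O`) gives 18100 nM. Compound 3 thus lies within the scatter of compound 1, while compound 2 stands at a higher number than both, beyond the scatter.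

The next compound, compound 4 (`COc1ccc(/C=C2\CCC/C(=C\c3cc(Cl)cc(Cl)c3)C2=O)cc1OC`), differs from compound 3 in one place: 3,5-dichlorophenyl in place of 2-methoxyphenyl on a double-bonded chain carbon bound to a double-bonded ring carbon. In words, it carries 3,5-dichlorophenyl in place of 2-methoxyphenyl on a double-bonded chain carbon bound to a double-bonded ring carbon.

Within the data shown here, only one measured step bears on this change, and only loosely: a 2.0-fold higher number from compound 1 to compound 2 (0.31 log units; beyond the scatter), with methoxy in place of bromo on an aromatic carbon. Read in reverse, that step suggests that swapping a methoxy-bearing aryl group for a halogen-bearing one could bring a modest move towards a lower number in this assay. Among the measured compounds shown here, no measured compound carries 3,5-dichlorophenyl, so the range must stay wide and reaches past the value of compound 3. The expected change is a 1.6-fold lower number from compound 3 to compound 4 (0.22 log units; within the scatter). For compound 4 the estimated value is 11000 nM, with an expected range from 4500 nM to 26000 nM.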

Compound 4, half-maximal inhibitory concentration: 8300 nM
Beside the measured number, compound 4's estimate is 1.3-fold (0.12 log units) above it; the range from low to high includes it.
By their numbers in this assay, from the lowest: compound 4; then compounds 3 and 1 (each within the scatter of the next); then compound 2.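

In this assay, 3,5-dichlorophenyl in place of 2-methoxyphenyl on a double-bonded chain carbon bound to a double-bonded ring carbon gives a 2.2-fold lower number from compound 3 to compound 4 (0.34 log units; beyond the scatter). This is the first step shown at this place, and it shows that the number responds to the aryl group held there, even though the change is modest and the group that leaves and the group that enters have the same count of heavy atoms and each hold one six-membered aromatic ring of carbon only. What differs in the count is that 2-methoxyphenyl brings one hydrogen-bond acceptor and 3,5-dichlorophenyl none, but nothing shown gives a reason for the move.

The compounds shown leave open whether the move follows from the entry of the two chlorine atoms or from the departure of the methoxy group, since the one step changes both together. On these data alone, it also remains open how this assay would respond at the same place to an unsubstituted phenyl group, to a phenyl group carrying a single chlorine, or to one carrying an amine.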